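The source may report more compounds than this note shows. Statements on the series, on what has been measured and on what is new or still open speak of the compounds shown alone.

Measured so far in a functional assay on a cell-free system (plasma) with sterol O-acyltransferase, Soat (Rattus norvegicus) as the target; a higher number here means that more compound is needed for the effect, a lower number that less compound is needed:
- compound 1 `Cc1cc(C)c(NC(=O)N(Cc2cc(-c3ccccc3)on2)C2CCCCCC2)c(C)c1` gives > 1 mg/kg
- compound 2 `Cc1cc(C)c(NC(=O)N(Cc2ccc(-c3n[nH]c(C)n3)cc2)C2CCCCCC2)c(C)c1` gives > 1 mg/kg
- compound 3 `Cc1cc(C)c(NC(=O)N(Cc2cccc(-c3cc[nH]n3)c2)C2CCCC2)c(C)c1` gives < 1 mg/kg

The value of compound 2 is a limit of this assay and not a number, as set out in the limit of > 1 mg/kg in this assay, at which 2 of the 3 values shown sit. The value of compound 1 is likewise a limit. The value of compound 3 is a limit at the other end, as set out in the limit of < 1 mg/kg in this assay, at which 1 of the 3 values shown sits. For the measured compounds named here, no two of the measured compounds differ in a single place, so no measured step is available, and compound 2 can only be placed among the limits, alongside compound 1 and apart from compound 3.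

Compound 4 `Cc1cc(C)c(NC(=O)N(Cc2ccc(-c3ccnn3C)cc2)C2CCCCCC2)c(C)c1` is the next compound to be run in this assay. It differs from compound 2 as follows: 1-methyl-1H-pyrazol-5-yl in place of 5-methyl-1H-1,2,4-triazol-3-yl on an aromatic carbon

With compound 2 sitting at a limit, the step to compound 4 cannot be anchored to a number; the expectation is a step no larger than the usual scatter, with the direction open. The estimate for compound 4 in this assay is 1.2 mg/kg, in the range 0.4 mg/kg to 3.5 mg/kg. That expected result corresponds to a step that the limit leaves unreadable from compound 2 to compound 4.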

Compound 4, dose for half-maximal effect: < 1 mg/kg
Compound 4: no number, only a limit; the forecaster's own chance of this, stated with the estimate: 60%; middle value at least 1.2-fold (0.07 log units) away from the limit.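

In this assay, for the compounds shown here, the first step between two measured compounds comes at this position, on an aromatic carbon para to a large group, where 1-methyl-1H-pyrazol-5-yl replaces 5-methyl-1H-1,2,4-triazol-3-yl: a number no higher from compound 2 to compound 4 (the limit leaves the size open). Compound 4 gives < 1 mg/kg, which is a limit and not a number, as is the value of compound 2. This single exchange is therefore enough to place the two compounds on opposite sides of the same cut-off, and the values shown now divide evenly: the limit of < 1 mg/kg in this assay, at which 2 of the 4 values shown sit.

How far apart compound 2 and compound 4 lie cannot be read, and these data give no reason for the difference. On these data alone, whether a carboxylic acid or a dimethylamino group at this position would fall on either side of the cut-off remains open.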